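This account rests on a few compounds, and the source may have more. Where it says the series, first, only, none or still open, it means among the compounds named here.

Working notes on the series in a functional assay on LoVo cells (Homo sapiens) for inhibition, read by MTT assay, with a stated time of 24 h; on this read-out lower numbers stand for stronger inhibition and higher numbers for weaker inhibition. Compound 1 `CC1(C)[C@H]2CC[C@]1(C)N(Cc1cn(-c3ccc(C#N)cc3)nn1)C(=O)C2` gives 90 nM, compound 2 `CC1(C)[C@H]2CC[C@]1(C)N(Cc1cn(-c3ccccc3C#N)nn1)C(=O)C2` gives 140 nM, and compound 3 `CC1(C)[C@H]2CC[C@]1(C)N(Cc1cn(-c3cccc(C#N)c3)nn1)C(=O)C2` gives 320 nM, the highest of the three numbers. Among these cyanophenyl compounds, the measured steps are a 1.6-fold higher number from compound 1 to compound 2 (0.19 log units; within the scatter), a 3.6-fold higher number from compound 1 to compound 3 (0.55 log units; beyond the scatter) and a 2.3-fold higher number from compound 2 to compound 3 (0.36 log units; beyond the scatter).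

Compound 4 `CC1(C)[C@H]2CC[C@]1(C)N(Cc1cn(-c3ccccc3Cl)nn1)C(=O)C2` carries 2-chlorophenyl in place of 3-cyanophenyl on an aromatic nitrogen. Going by the values given here, no measured compound carries 2-chlorophenyl, so the effect of the chlorine itself remains unknown. The closest guide is compound 2, the 2-cyanophenyl compound at 140 nM, and the gap to it is a 2.3-fold higher number from compound 2 to compound 3 (0.36 log units; beyond the scatter). A modest move to a lower number is therefore expected in this assay, though the uncertainty is wide. The expected step is a 1.8-fold lower number from compound 3 to compound 4 (0.25 log units; within the scatter). Compound 4 is estimated at 180 nM, with an expected range from 70 nM to 450 nM.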

Compound 4, half-maximal inhibitory concentration: 190 nM
Beside the measured number, compound 4's estimate is 1.1-fold (0.02 log units) below it; the measured number falls inside the stated range.
By their numbers in this assay, from the lowest: compounds 1, 2, 4 and 3 (each within the scatter of the next, the first and the last beyond it).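

In this assay, chloro in place of cyano on an aromatic carbon gives a 1.4-fold higher number from compound 2 to compound 4 (0.13 log units; within the scatter) and so shows that, at this position on the phenyl ring, the nitrile can be exchanged for chloro with no step beyond the scatter. Against the other two cyanophenyl compounds the result divides, with a 1.7-fold lower number from compound 3 to compound 4 (0.23 log units; within the scatter) inside the scatter and a 2.1-fold higher number from compound 1 to compound 4 (0.32 log units; beyond the scatter) beyond it, so 2-chlorophenyl can be separated only from 4-cyanophenyl. No supporting measurement bears on why these steps take this size.

The compounds shown leave open whether chloro at the other ring positions would follow the pattern of the cyanophenyl compounds, since 2-chlorophenyl is the only chlorophenyl group here. They also leave open what an unsubstituted phenyl, or an amine or a carboxylic acid on the phenyl ring, would give in this assay on the same core.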